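Notes on a second chloro group

A few compounds are considered here, and "the series" means these few. Any claim that something is new, unique, unknown or untested is made for them only; others in the source may bear on it.

In a physicochemical assay for lipophilicity (a lower number here means a more polar compound, a higher number a more lipophilic compound), three compounds sharing one core have been measured. Compound 1 `Cc1ccc(C2=NC(c3ccccc3)CO2)cc1` gives 4.11, compound 2 `Clc1ccccc1C1=NC(c2ccccc2)CO1` gives 3.56, and compound 3 `Clc1ccc(C2=NC(c3ccccc3)CO2)cc1` gives 4.48. Compound 3 stands highest of the three, beyond the scatter from both others.

Compound 4 `Clc1ccc(C2=NC(c3ccccc3)CO2)c(Cl)c1` is compound 3 with one change, chloro in place of hydrogen on an aromatic carbon. The new chloro sits ortho to a large group and meta to a chloro group.

Within the data shown here, no measured step matches this change exactly. The nearest is a number 0.37 log units higher from compound 1 to compound 3 (beyond the scatter), a modest rise, but there chloro replaces methyl rather than hydrogen. That step points upward. Compound 2 offers a second, weaker hint, since its single chloro is also ortho to a large group and compound 2 reads only 3.56. That low reading points the other way, and the two hints together argue against a large step.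

The expected step is small and upward, a number 0.17 log units higher from compound 3 to compound 4 (within the scatter), and it may not clear the scatter. Compound 4 is estimated at 4.65, with an expected range from 4.15 to 5.15.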

Compound 4, partition coefficient: 4.4
Compound 4: the middle estimate sits 0.25 log units above what was measured; the measured number falls inside the stated range.
By their numbers in this assay, from the lowest: compound 2; then compounds 1, 4 and 3 (each within the scatter of the next, the first and the last beyond it).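

In this assay the new chloro, ortho to a large group, does not separate the two compounds on either side of the change: a number 0.08 log units lower from compound 3 to compound 4 (within the scatter). The other step to the same compound behaves differently, a number 0.84 log units higher from compound 2 to compound 4 (beyond the scatter), so a chloro in place of hydrogen added to compound 2 moves the number beyond the scatter, while the chloro added to compound 3 does not, and the two places on the aromatic ring do not count alike in these two steps. No measurement shown gives a reason why the two steps differ in size.

As far as these compounds go, both steps rest on compound 4 alone, so it stays open whether the same contrast would hold with methyl in place of the first chloro on the shared core. Also open, from the compounds shown here alone, is how a group other than chloro would read ortho to a large group, such as a methoxy group, an amine or a carboxylic acid, and whether its number would stay as close to that of compound 3.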